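A few compounds are considered here, and "the series" means these few. Any claim that something is new, unique, unknown or untested is made for them only; others in the source may bear on it.

In a functional assay on MGC-803 cells (Homo sapiens) for cytotoxicity, read by MTT assay, with a stated time of 72 h (on this read-out lower numbers stand for stronger inhibition and higher numbers for weaker inhibition), compound 1 (`C=C1C(=O)[C@@]23C(=O)OC[C@]4(C(=O)CCC(C)(C)[C@H]4C=O)[C@@H]2CC[C@@H]1[C@H]3OC(C)=O`) gives 1660 nM, compound 2 (`C=C1C(=O)[C@@]23C(=O)OC[C@]4(C(=O)CCC(C)(C)[C@H]4C=O)[C@@H]2CC[C@@H]1[C@H]3OC(=O)c1ccccc1`) gives 1920 nM, and compound 3 (`C=C1C(=O)[C@@]23C(=O)OC[C@]4(C(=O)CCC(C)(C)[C@H]4C=O)[C@@H]2CC[C@@H]1[C@H]3OC(=O)c1ccc(C(F)(F)F)cc1`) gives 4930 nM, the highest of the three numbers. Compound 4 (`C=C1C(=O)[C@@]23C(=O)OC[C@]4(C(=O)CCC(C)(C)[C@H]4C=O)[C@@H]2CC[C@@H]1[C@H]3OC(=O)c1ccc(F)cc1`) differs from compound 3 by one change: fluoro in place of trifluoromethyl on an aromatic carbon. The closest evidence is a 2.6-fold higher number from compound 2 to compound 3 (0.41 log units; beyond the scatter), a modest step on adding trifluoromethyl in place of hydrogen. The step of a 3.0-fold higher number from compound 1 to compound 3 (0.47 log units; beyond the scatter) is similar in size, whereas a 1.2-fold higher number from compound 1 to compound 2 (0.06 log units; within the scatter) stays within the scatter. A modest step towards a lower number is therefore expected, estimated as a 2.1-fold lower number from compound 3 to compound 4 (0.31 log units; beyond the scatter). Compound 4 is estimated at 2400 nM, with an expected range of 1200 nM to 4800 nM.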

Compound 4, half-maximal inhibitory concentration: 3960 nM
Estimate against measurement, compound 4: 1.7-fold (0.22 log units) below; low and high end bracket the measured number.
By their numbers in this assay, from the lowest: compounds 1 and 2 (each within the scatter of the next); then compounds 4 and 3 (each within the scatter of the next).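

In this assay, exchanging trifluoromethyl for fluoro on this aromatic carbon brings no readable change (a 1.2-fold lower number from compound 3 to compound 4 (0.10 log units; within the scatter)). Fluoro in place of hydrogen is itself a modest step upwards (a 2.1-fold higher number from compound 2 to compound 4 (0.31 log units; beyond the scatter)), so a higher number at this position is no longer seen with trifluoromethyl alone, and the 4-fluorophenyl ester also stands modestly above the acetate (a 2.4-fold higher number from compound 1 to compound 4 (0.38 log units; beyond the scatter)). No measured evidence here accounts for these steps. As far as these compounds go, what an amine or a methoxy group on the same aromatic carbon would do stays open, and so does whether any group there can bring the number below that of the unsubstituted phenyl ester.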